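The source may hold more compounds than are shown below. What is called first, only, known or untested is meant among the compounds shown, and "the series" means these compounds.

Three compounds share one core and differ only in the group attached through the oxygen beside the dimethylallyl side chain. Compound 1 `CCC(C)(O)CC(=O)O[C@H](CC=C(C)C)C1=CC(=O)c2c(O)ccc(O)c2C1=O` carries a (2-hydroxy-2-methylbutyl)carbonyl there; in a functional assay on HeLa cells (Homo sapiens) for cytotoxicity, read by MTT assay (on this read-out higher numbers stand for weaker inhibition and lower numbers for stronger inhibition), compound 1 gives 25200 nM. Compound 2 `CC(C)=CC[C@@H](OC(=O)C1CCOC1)C1=CC(=O)c2c(O)ccc(O)c2C1=O` gives 73500 nM, and compound 3 `CC(C)=CC[C@@H](OC(=O)C1CCCO1)C1=CC(=O)c2c(O)ccc(O)c2C1=O` gives 17000 nM. Compound 1 thus stands second highest of the three; a 1.5-fold lower number from compound 1 to compound 3 (0.17 log units; within the scatter), whereas a 2.9-fold higher number from compound 1 to compound 2 (0.46 log units; beyond the scatter) and a 4.3-fold lower number from compound 2 to compound 3 (0.64 log units; beyond the scatter). Compound 4 `CC(C)=CC[C@@H](OCCO)C1=CC(=O)c2c(O)ccc(O)c2C1=O` is new: 2-hydroxyethyl in place of (2-hydroxy-2-methylbutyl)carbonyl on an oxygen on a saturated carbon. For the measured compounds named here, no measured step removes the carbonyl itself, so the three steps bear only loosely, and all were modest. The expected outcome is a 1.2-fold higher number from compound 1 to compound 4 (0.08 log units; within the scatter), a small change. Compound 4 is estimated at 30000 nM, within 10000 nM to 90000 nM.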

Compound 4, half-maximal inhibitory concentration: 18600 nM
Beside the measured number, compound 4's estimate is 1.6-fold (0.21 log units) above it; measured number inside the range.
By their numbers in this assay, from the lowest: compounds 3, 4 and 1 (each within the scatter of the next); then compound 2.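

In this assay, losing the carbonyl from this oxygen leaves the number within the scatter: putting 2-hydroxyethyl in place of (2-hydroxy-2-methylbutyl)carbonyl gives a 1.4-fold lower number from compound 1 to compound 4 (0.13 log units; within the scatter), and putting it in place of (oxolan-2-yl)carbonyl gives a 1.1-fold higher number from compound 3 to compound 4 (0.04 log units; within the scatter). The one clear gap lies with the (oxolan-3-yl)carbonyl group, at a 4.0-fold lower number from compound 2 to compound 4 (0.60 log units; beyond the scatter). No supporting evidence is available to explain these results. Still open, as far as these compounds go, is how an amine, a carboxylic acid or a longer chain on this oxygen would read.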